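The compounds below may be only part of what the source reports. "The series", "measured", "known", "first", "only" and "open" are said of these compounds alone.

In a functional assay on HCT-116 cells (Homo sapiens) for inhibition, read by MTT assay, with a stated time of 72 h (a lower number here means a stronger inhibitor of growth, a higher number a weaker inhibitor of growth), compound 3 `O=C(O)CCc1ccncc1-c1ccc2ccccc2c1` gives only a limit of the assay, > 30000 nM. Compound 1 `COC1CN(C(=O)/C=C/c2ccncc2-c2ccc3ccccc3c2)C1` likewise reaches only a limit, > 30000 nM. Compound 3 thus stands at the limit of > 30000 nM in this assay, at which 2 of the 3 values shown sit, rather than at a number. Compound 2 `CNC(=O)CCc1ccncc1-c1ccc2ccccc2c1` gives 19300 nM. Among the measured compounds shown here, the one measured step that bears here is an at least 1.5-fold higher number from compound 2 to compound 3 (0.19 log units; that floor lies within the scatter), which swaps the methylamide of compound 2 for the acid of compound 3 and stays within the scatter. Compound 4 `CNC(=O)/C=C/c1ccncc1-c1ccc2ccccc2c1` reverses that swap and also adds a double bond: 2-(methylcarbamoyl)ethenyl in place of 2-carboxyethyl on an aromatic carbon. The return to a methylamide points toward compound 2 and its 19300 nM, while the double bond has only compound 1 as a guide. Compound 4 is therefore expected to give 20000 nM (range 8000 nM to 40000 nM). The expected step is an at least 1.5-fold lower number from compound 3 to compound 4 (0.17 log units; that floor lies within the scatter).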

Compound 4, concentration for 50% growth inhibition: 6550 nM
Beside the measured number, compound 4's estimate is 3.1-fold (0.48 log units) above it; measured number below the stated range.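

In this assay, among the compounds shown here, adding the double bond while keeping the methylamide gives a 2.9-fold lower number from compound 2 to compound 4 (0.47 log units; beyond the scatter) and is the first step at this position that lies beyond the scatter. With that double bond kept, methylamino in place of 3-methoxyazetidin-1-yl gives an at least 4.5-fold lower number from compound 1 to compound 4 (0.66 log units; beyond the scatter) and so the group on the carbonyl carbon also counts, while replacing 2-carboxyethyl gives an at least 4.5-fold lower number from compound 3 to compound 4 (0.66 log units; beyond the scatter) as a further step beyond the scatter. These last two steps are only floors, because compound 1 and compound 3 each sit at a limit: the limit of > 30000 nM in this assay, at which 2 of the 4 values shown sit.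

From the compounds shown here alone, how a carboxylic acid on the ethenyl chain, an unsubstituted amide or a longer chain would read at this position remains open.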